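From 4-methylpiperazin-1-yl to isopropoxy on a shared core

The source may report more compounds than this note shows. Statements on the series, on what has been measured and on what is new or still open speak of the compounds shown alone.

In a functional assay on MDA-MB-231 cells (Homo sapiens) for inhibition, read by MTT assay, with a stated time of 72 h (on this read-out lower numbers stand for stronger inhibition and higher numbers for weaker inhibition), compound 1 `COc1ccc(-c2cc(C(=O)N3CCC4(CC3)CC(=O)c3nn(C(C)(C)C)cc3O4)c3ccccc3n2)cc1OC` gives 7130 nM as its reading, compound 2 `CC(C)(C)n1cc2c(n1)C(=O)CC1(CCN(C(=O)c3cc(-c4ccc(N)cc4)nc4ccccc34)CC1)O2` gives 4960 nM and compound 3 `CN1CCN(c2cc(C(=O)N3CCC4(CC3)CC(=O)c3nn(C(C)(C)C)cc3O4)c3ccccc3n2)CC1` gives 8130 nM on the same scale. Compound 3 does not stand apart from the other two, with a 1.1-fold higher number from compound 1 to compound 3 (0.06 log units; within the scatter) and a 1.6-fold higher number from compound 2 to compound 3 (0.21 log units; within the scatter) as the steps that reach it. Compound 4 `CC(C)Oc1cc(C(=O)N2CCC3(CC2)CC(=O)c2nn(C(C)(C)C)cc2O3)c2ccccc2n1` has isopropoxy in place of 4-methylpiperazin-1-yl on an aromatic carbon next to the ring nitrogen, and isopropoxy in place of 4-methylpiperazin-1-yl on an aromatic carbon sums up that exchange. Within the data shown here, all the measured steps change the group on this same carbon. Besides those two there is a 1.4-fold lower number from compound 1 to compound 2 (0.16 log units; within the scatter) as the third, and none of them leaves the scatter. Among the measured compounds shown here, no measured compound carries isopropoxy, so these steps are only indirect guides. No step beyond the scatter is therefore expected in this assay for this exchange. The estimate means a 1.3-fold lower number from compound 3 to compound 4 (0.10 log units; within the scatter) as an expected change. For compound 4 the estimated value is 6500 nM with an expected range from 3300 nM to 13000 nM as the likely span.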

Compound 4, half-maximal inhibitory concentration: > 10000 nM
Compound 4 gave a limit, no number; the forecaster's own chance of this, stated with the estimate: 10%; middle value at least 1.5-fold (0.18 log units) away from the limit.
By their numbers in this assay, from the lowest: compounds 2, 1 and 3 (each within the scatter of the next). At a limit, above all of these: compound 4.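

In this assay compound 4 gives a limit, not a number: the limit of > 10000 nM in this assay, at which 1 of the 4 values shown sits. The new steps are an at least 1.2-fold higher number from compound 3 to compound 4 (0.08 log units; that floor lies within the scatter), an at least 2.0-fold higher number from compound 2 to compound 4 (0.30 log units; that floor lies within the scatter) and an at least 1.4-fold higher number from compound 1 to compound 4 (0.14 log units; that floor lies within the scatter), and since each is only a floor, the data cannot show how large any of these changes really is. Among these compounds, what is new at this carbon is that isopropoxy, the one group here without a ring, is also the only one that gives a limit, whereas the three groups carrying a ring all give readable numbers.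

Still open, going by these compounds, is how far beyond the limit the true value of compound 4 lies. Also open, on these data alone, is whether another group without a ring on this carbon, such as dimethylamino or a longer chain like butoxy, would give a limit as well.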